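The source may report more compounds than this note shows. Statements on the series, on what has been measured and on what is new or still open speak of the compounds shown alone.

Compound 1 `O=C(CBr)Nc1ccc(C(=O)/C=C/c2ccc(Cl)cc2)cc1` is the reference point of this small set. In a functional assay on the whole organism (strain albino) for inhibition, with Rattus norvegicus as the target, read by paw edema, with stated times of 30 min and 4 h, at a dose of 100 mg/kg by the oral route (a higher number here means more inhibition at the dose given (going by the name of the read-out), a lower number less inhibition), compound 1 gives 59%, the highest of the three numbers measured. Compound 2 `COc1ccc(/C=C/C(=O)c2ccc(NC(=O)CBr)cc2)cc1`, in which methoxy replaces chloro on an aromatic carbon, gives 41% in this assay, a step of a number 18 percentage points lower from compound 1 to compound 2 (beyond the scatter). Compound 3 `O=C(CBr)Nc1ccc(C(=O)/C=C/c2ccco2)cc1`, with furan-2-yl in place of 4-chlorophenyl on the double-bonded chain carbon, gives 33%, a step of a number 26 percentage points lower from compound 1 to compound 3 (beyond the scatter). Both measured steps alter the aryl end of the shared core and leave the amide side untouched.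

Compound 4 `CC(O[N+](=O)[O-])C(=O)Nc1ccc(C(=O)/C=C/c2ccc(Cl)cc2)cc1` departs from compound 1 at the other end: 1-(nitrooxy)ethyl in place of bromomethyl on a carbonyl carbon. Going by the values given here, no measured step touches this carbonyl carbon, so the two known steps offer no direct guide to its size or direction. With nothing beyond the scatter to point either way, the expected step of a number 5 percentage points lower from compound 1 to compound 4 (within the scatter) is small. The value for compound 4 in this assay is therefore estimated at 54%, with a range from 34% to 72%.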

Compound 4, a percentage reported as inhibition, in the whole organism at one dose (the size of the read-out at that dose, not a potency): 61%
Compound 4: the middle estimate sits 7 percentage points below what was measured; measured number inside the range.
By their numbers in this assay, from the lowest: compounds 3 and 2 (each within the scatter of the next); then compounds 1 and 4 (each within the scatter of the next).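

In this assay, the exchange of bromomethyl for 1-(nitrooxy)ethyl on the carbonyl carbon gives a number 2 percentage points higher from compound 1 to compound 4 (within the scatter) and so leaves the reading unchanged within the scatter. This shows that the bromine is not needed for this level of inhibition of paw edema, even though the entering group has 6 heavy atoms in place of 2 and brings 3 hydrogen-bond acceptors. Unlike the two earlier changes at the aryl end, both beyond the scatter, this change at the amide side moves the number by no measurable amount, and no available evidence explains why the two groups read alike.

From the compounds shown here alone, what remains open is whether 1-(nitrooxy)ethyl would read the same on a core carrying 4-methoxyphenyl or furan-2-yl instead of 4-chlorophenyl. Also open, going by these compounds, is how far this carbonyl carbon accepts other groups, such as a plain methyl, an amine or a carboxylic acid.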